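A Methoxy Group Added to the Pendant Phenyl of Compound 2

The compounds below may be only part of what the source reports. "The series", "measured", "known", "first", "only" and "open" are said of these compounds alone.

Compound 1 `COc1cc(/C=C/C(=O)c2cccc(-n3cc(-c4ccc(Cl)cc4)[nH]c3=O)c2)ccc1O` gives 2070 nM in a functional assay on 786-0 cells (Homo sapiens) for inhibition; on this read-out higher numbers stand for weaker inhibition of growth and lower numbers for stronger inhibition of growth.
Compound 2 `COc1cc(/C=C/C(=O)c2cccc(-n3cc(-c4ccccc4)[nH]c3=O)c2)cc(OC)c1OC` gives 1380 nM in this assay.
Compound 3 `COc1cc(/C=C/C(=O)c2cccc(-n3cc(-c4ccccc4)[nH]c3=O)c2)ccc1O` gives 1350 nM in this assay.

All three numbers sit close together, and compound 2 lies within the usual scatter of compound 3 and of compound 1 alike. Compound 4 `COc1ccc(-c2cn(-c3cccc(C(=O)/C=C/c4cc(OC)c(OC)c(OC)c4)c3)c(=O)[nH]2)cc1` differs from compound 2 by methoxy in place of hydrogen on an aromatic carbon. Going by the values given here, the one measured step on the same ring, a 1.5-fold lower number from compound 1 to compound 3 (0.19 log units; within the scatter), stayed within the scatter; no measured step adds a methoxy group there. Compound 4 is therefore expected to show no shift beyond the scatter, a 1.1-fold lower number from compound 2 to compound 4 (0.03 log units; within the scatter). For compound 4 the estimate in this assay is 1300 nM, with a range from 500 nM to 3500 nM.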

Compound 4, concentration for 50% growth inhibition: 1610 nM
Compound 4: the middle estimate sits 1.2-fold (0.09 log units) below what was measured; low and high end bracket the measured number.
By their numbers in this assay, from the lowest: compounds 3, 2, 4 and 1 (each within the scatter of the next).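

In this assay the change from phenyl to 4-methoxyphenyl gives a 1.2-fold higher number from compound 2 to compound 4 (0.07 log units; within the scatter) and thus stays within the scatter. Together with the chloro step, which was read on a different background, this shows that a methoxy group at this place also leaves the number within the scatter. No evidence bears on why the number holds.

Going by these compounds, it remains open whether an amine or a carboxylic acid at this place would move the number beyond the scatter. On these data alone, the same methoxy change on compound 3 also remains open.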